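One Number, One Open Step: Phenyl to 4-Nitrophenyl

This account rests on a few compounds, and the source may have more. Where it says the series, first, only, none or still open, it means among the compounds named here.

In a functional assay on HL-60 cells (Homo sapiens) for inhibition (on this read-out lower numbers stand for stronger inhibition and higher numbers for weaker inhibition), compound 1 `CC(C)CN(C)Cc1ccc(C2=CCCN(C)C2)cc1` is recorded as "not determined" (no result reported) and compound 2 `CC(C)CCCN(C)Cc1ccc(C2=CCCN(C)C2)cc1` as "not determined" (no result reported) so neither offers a comparison. For the measured compounds named here, compound 3 `CN1CCC=C(c2ccc(CN(C)C/C=C/c3ccccc3)cc2)C1` gives 680 nM in this assay and thus holds the only number in the set, with nothing to rank it against. Compound 4 `CN1CCC=C(c2ccc(CN(C)C/C=C/c3ccc([N+](=O)[O-])cc3)cc2)C1` is reached from compound 3 through nitro in place of hydrogen on an aromatic carbon and this takes phenyl to 4-nitrophenyl. Going by the values given here, no measured step in this set shows what such a change does, so any expectation rests on the structural change alone. On that thin basis, no shift beyond the scatter is expected in this assay and no firm direction can be given. The estimated step of a 1.1-fold lower number from compound 3 to compound 4 (0.05 log units; within the scatter) is therefore expected to be small. For compound 4 the expected value is 600 nM with an estimated range from 200 nM to 1800 nM in this measurement.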

Compound 4, half-maximal inhibitory concentration: 1280 nM
Beside the measured number, compound 4's estimate is 2.1-fold (0.33 log units) below it; measured number inside the range.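

With this pair, this assay gains its first readable step, a 1.9-fold higher number from compound 3 to compound 4 (0.27 log units; within the scatter). It shows that nitro can take the place of hydrogen on this aromatic carbon, para to a large group, without a difference beyond the usual scatter. That single step gives no direction for the change, and no supporting evidence bears on the result.

The compounds shown leave open whether an amine, a carboxylic acid or a methoxy group on the same carbon would give a step beyond the scatter. They also leave open whether nitro on another carbon of this ring would give a similarly small step, or whether this result would hold with a different group in place of the 3-phenylallyl chain's phenyl ring.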